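Carbonate to carbamate swap on two related cores

The source may report more compounds than this note shows. Statements on the series, on what has been measured and on what is new or still open speak of the compounds shown alone.

Compound 1 `COC(=O)OC[C@H]1[C@H]2CC[C@@H](C)[C@]1(C)CC/C(C)=C/CC[C@@]1(C)O[C@@H]1C2=O` gives 26 nM in an assay (Oryctolagus cuniculus) for inhibition of platelet-activating factor receptor (Cavia porcellus); a lower number here means a stronger inhibitor, a higher number a weaker inhibitor. Compound 2 `C/C1=C\CC[C@@]2(C)O[C@@H]2C(=O)[C@@H]2CC[C@@H](C)[C@](C)(CC1)[C@H]2COC(=O)N(C)C` differs from it by dimethylamino in place of methoxy on a carbonyl carbon and gives 180 nM in this assay; the step from compound 1 to compound 2 is a 6.9-fold higher number from compound 1 to compound 2 (0.84 log units; beyond the scatter). Compound 3 `COC(=O)OC[C@H]1[C@H]2CC[C@@H](C)[C@]1(C)CC/C(C)=C/CC[C@@]1(C)O[C@@H]1[C@@H]2O` gives 130 nM in this assay. The difference between the core of compound 1 and the core of compound 3 is not broken down here. Compound 3 shows a higher number than compound 1, beyond the scatter, while the values of compound 3 and compound 2 lie within the scatter of each other, so no order is drawn between those two.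

Compound 4 `C/C1=C\CC[C@@]2(C)O[C@@H]2[C@H](O)[C@@H]2CC[C@@H](C)[C@](C)(CC1)[C@H]2COC(=O)N(C)C` is not yet measured. It carries dimethylamino in place of methoxy on a carbonyl carbon, the same change as from compound 1 to compound 2, at the same place, a carbonyl carbon whose other neighbours are oxygen next to a carbonyl group. Among the compounds with values here, only one measured precedent for this change exists, and it sits on a core whose relation to that of compound 3 is not broken down, so the transfer is uncertain. The step is nonetheless expected to be of similar direction and size, a higher number, because a 6.9-fold higher number from compound 1 to compound 2 (0.84 log units; beyond the scatter) lies clearly beyond the scatter; for compound 4 the expected step is a 5.8-fold higher number from compound 3 to compound 4 (0.76 log units; beyond the scatter). Compound 4 is estimated at 750 nM, with a range from 250 nM to 2500 nM.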

Compound 4, half-maximal inhibitory concentration: 180 nM
The estimate for compound 4 lay 4.2-fold (0.62 log units) above the measured number, and the stated range ends above it.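

On the core of compound 3, dimethylamino in place of methoxy on a carbonyl carbon gives a 1.4-fold higher number from compound 3 to compound 4 (0.14 log units; within the scatter) in this assay, so this pair cannot be ordered, unlike the pair on the core of compound 1. The effect of the change therefore did not carry over unchanged from one core to the other, and its size in this series has to be read core by core: the same change on two cores in this assay, a 6.9-fold higher number (0.84 log units; beyond the scatter) from compound 1 to compound 2 and a 1.4-fold higher number (0.14 log units; within the scatter) from compound 3 to compound 4, 5.0-fold (0.70 log units) apart, beyond the scatter of two such steps

Within the data shown here, this rests on only two matched pairs, so it shows that the core can matter for this change but gives no general rule, and the difference between the two cores is not broken down, so nothing here says which part of that difference accounts for the gap.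

The compounds shown leave open whether other groups on the same carbonyl carbon, such as methylamino, ethoxy or a cyclic amine like pyrrolidinyl, would follow the step seen on the core of compound 1 or the one seen on the core of compound 3. They also leave open whether the gap between the two cores is particular to the exchange of methoxy for dimethylamino or extends to such groups.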